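Amide substituent variation on the shared core

This account rests on a few compounds, and the source may have more. Where it says the series, first, only, none or still open, it means among the compounds named here.

Measured in an assay on CHO-K1 cells for displacement of a labelled ligand from prostaglandin E2 receptor EP1 subtype (Homo sapiens), read by scintillation counting, with a stated time of 45 min; on this read-out higher numbers stand for weaker inhibition and lower numbers for stronger inhibition:
Compound 1 `CCCc1cc2cc(Cl)cc(Cn3nc(C(=O)O)cc3C)c2o1` gives 25.1 nM.
Compound 2 `Cc1cc(C(=O)NC2CC2)nn1Cc1cc(Cl)cc2cc(-c3ccccc3)oc12` gives 5.01 nM.
Compound 3 `Cc1cc(C(=O)NCC2CCNCC2)nn1Cc1cc(Cl)cc2cc(-c3ccccc3)oc12` gives 20 nM.

Compound 3 stands second highest of the three numbers. Its value and that of compound 1 lie within the scatter of each other, so no order between those two is claimed, while compound 2 sits below compound 3 by a step beyond the scatter. Among the measured compounds shown here, the only step so far at the amide nitrogen, a 4.0-fold higher number from compound 2 to compound 3 (0.60 log units; beyond the scatter), shows that going from cyclopropyl to (piperidin-4-yl)methyl weakened inhibition in this assay.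

Compound 4 `Cc1cc(C(=O)NC[C@H]2CCCO2)nn1Cc1cc(Cl)cc2cc(-c3ccccc3)oc12` carries the change (oxolan-2-yl in place of piperidin-4-yl on a saturated chain carbon bound to an amide-type nitrogen). For the measured compounds named here, no measured pair covers this exact swap; the one step that bears on it is a 4.0-fold higher number from compound 2 to compound 3 (0.60 log units; beyond the scatter), and only indirectly: the ring that leaves in compound 4 is the one whose introduction raised the number, and what enters is a ring with fewer heavy atoms and no donor. The expectation is therefore a partial move back toward the value of compound 2, with a 2.0-fold lower number from compound 3 to compound 4 (0.30 log units; within the scatter) as the estimated step. Compound 4 is expected to give 10 nM, with a range of 4 nM to 25 nM.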

Compound 4, half-maximal inhibitory concentration: 6.31 nM
Compound 4: middle estimate off by 1.6-fold (0.20 log units), on the high side; measured number inside the range.
By their numbers in this assay, from the lowest: compounds 2 and 4 (each within the scatter of the next); then compounds 3 and 1 (each within the scatter of the next).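

In this assay, the higher number of compound 3 does not extend to every ring on this saturated chain carbon: oxolan-2-yl in place of piperidin-4-yl gives a 3.2-fold lower number from compound 3 to compound 4 (0.50 log units; beyond the scatter) and is a modest change. The comparison with the cyclopropyl amide reads a 1.3-fold higher number from compound 2 to compound 4 (0.10 log units; within the scatter), so cyclopropyl and (oxolan-2-yl)methyl cannot be told apart at the amide-type nitrogen, and the chain carbon carried by both compound 3 and compound 4 does not by itself go with the higher number. Nothing at hand indicates why the two rings differ, and the swap alters ring size, hetero atom and donor count together, so these contributions remain unseparated.

The compounds shown leave open whether the value of compound 4 holds for the opposite configuration at its defined stereocentre, and whether the ring is needed at all on this chain carbon. An open-chain 2-methoxyethyl group would address the second question, while a dimethylamino group or a carboxylic acid at the end of the same chain would show how far this position tolerates an amine or an acid outside a ring.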